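The source may hold more compounds than are shown below. What is called first, only, known or untested is meant among the compounds shown, and "the series" means these compounds.

Measured so far:
compound 1, `Cc1cccc(-c2nc(CNc3ccc(C(=O)NO)cc3)n(-c3ccccc3)n2)c1` — 64.1%
compound 2, `CC(C)c1ccc(-n2nc(-c3ccccc3)nc2CNc2ccc(C(=O)NO)cc2)cc1` — 52.6%

In an assay on Sf9 cells for inhibition of protein deacetylase HDAC6 (Homo sapiens), read by fluorescence, with a stated time of 40 min, tested at 100 nM (a higher number here means more inhibition at the concentration tested (going by the name of the read-out), a lower number less inhibition), compound 1 gives 64.1%. Compound 2 gives 52.6% in this assay, a number lower than that of compound 1 by more than the scatter, so compound 1 stands highest of the two numbers shown. Compound 3, `O=C(NO)c1ccc(NCc2nc(-c3ccco3)nn2-c2ccccc2)cc1`, has not yet been measured in this assay. It differs from compound 1 in one place: furan-2-yl in place of 3-methylphenyl on an aromatic carbon. For the measured compounds named here, no step between measured compounds matches this change, so nothing in the two numbers shows how it should act; the nearest comparison, compound 2, alters a different ring. He therefore expects a modest change for compound 3, if any, downward rather than upward, and probably not beyond the scatter, as a number 9.1 percentage points lower from compound 1 to compound 3 (within the scatter). His estimate for compound 3 in this assay is 55%, with a range from 35% to 72%.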

Compound 3, a percentage reported as inhibition, at one concentration (the size of the read-out at that concentration, not a potency): 59.9%
Compound 3: middle estimate off by 4.9 percentage points, on the low side; low and high end bracket the measured number.
By their numbers in this assay, from the lowest: compounds 2, 3 and 1 (each within the scatter of the next, the first and the last beyond it).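

In this assay, for the compounds shown here, furan-2-yl in place of 3-methylphenyl on this aromatic carbon gives a number 4.2 percentage points lower from compound 1 to compound 3 (within the scatter), the first step that can be read at this position. It shows that a five-membered aromatic ring with 1 hetero atom, at 5 heavy atoms, can stand here in place of a six-membered aromatic ring of carbon only, at 7 heavy atoms, without a difference beyond the scatter. Nothing available on these compounds accounts for this result.

Still open, going by these compounds, is what the number in this assay would be with a group at this position that is not aromatic, such as cyclohexyl or a dimethylamino group. Also open, on these data alone, is what a single change on the phenyl group alone, such as a methoxy group, would do, as compound 2 differs from compound 1 in two places.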